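Ether group variation across the series

The source may report more compounds than this note shows. Statements on the series, on what has been measured and on what is new or still open speak of the compounds shown alone.

Measured so far in a functional assay on PC-3 cells (Homo sapiens) for inhibition, read by MTT assay, with a stated time of 72 h; a lower number here means a stronger inhibitor, a higher number a weaker inhibitor:
compound 1, `CCOc1ccc(C2CC2C(=O)NNC(=O)c2ccncc2)cc1`, gives > 100000 nM, which is a limit of the assay rather than a number.
compound 2, `COc1ccc(C2CC2C(=O)NNc2nncc3ccccc23)cc1`, gives 64000 nM.
compound 3, `O=C(NNc1nncc2ccccc12)C1CC1c1ccc(OC(F)(F)F)cc1`, gives 92000 nM.

Compound 3 holds the higher of the two numbers recorded; its nearest neighbour is compound 2, and the step of a 1.4-fold higher number from compound 2 to compound 3 (0.16 log units; within the scatter) lies within the scatter, so no order between the two can be read. Compound 1 sits at the limit of > 100000 nM in this assay, at which 1 of the 3 values shown sits, and contributes no number for comparison.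

The next compound, compound 4, `CC(C)=CCOc1ccc(C2CC2C(=O)NNc2nncc3ccccc23)cc1`, differs from compound 3 in one place: 3-methylbut-2-en-1-yl in place of trifluoromethyl on an oxygen on an aromatic ring. Going by the values given here, the only measured step that touches the same position is the one from compound 2 to compound 3, where trifluoromethyl replaced methyl on the oxygen on the aromatic ring; that step, a 1.4-fold higher number from compound 2 to compound 3 (0.16 log units; within the scatter), did not move the number beyond the scatter. With one change at this oxygen showing no effect, and nothing measured yet for a chain of this kind, the working expectation for compound 4 is no shift beyond the scatter, with a wide allowance. Relative to compound 3, the expected step for compound 4 is a 1.2-fold lower number from compound 3 to compound 4 (0.06 log units; within the scatter). Compound 4 is therefore estimated at 80000 nM, with a range from 25000 nM to 250000 nM.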

Compound 4, half-maximal inhibitory concentration: 81000 nM
Compound 4: middle estimate off by 1.0-fold (0.01 log units), on the low side; the range from low to high includes it.
By their numbers in this assay, from the lowest: compounds 2, 4 and 3 (each within the scatter of the next). At a limit, above all of these: compound 1.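

In this assay, the oxygen on the aromatic ring has now carried methyl, trifluoromethyl and 3-methylbut-2-en-1-yl, and both new steps stay within the scatter (a 1.1-fold lower number from compound 3 to compound 4 (0.06 log units; within the scatter); a 1.3-fold higher number from compound 2 to compound 4 (0.10 log units; within the scatter)). This adds the first chain at this oxygen with a double bond outside aromatic rings, and replacing trifluoromethyl with this all-carbon chain produces no readable change. Compounds 2, 3 and 4 therefore show no order, and among these three compounds, none goes against the reading that the group on this oxygen makes no measurable difference.

Still open, from the compounds shown here alone, is whether an amine or a carboxylic acid at the end of a longer chain on this oxygen, or a hydroxyl group in place of the ether, would move the number beyond the scatter. Compound 1 stands as a limit and not a number, and it differs from the other compounds in more than one place: the limit of > 100000 nM in this assay, at which 1 of the 4 values shown sits.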